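Methyl for Phenyl on an Aromatic Nitrogen: Compound 4

This account rests on a few compounds, and the source may have more. Where it says the series, first, only, none or still open, it means among the compounds named here.

Compound 1 `Cc1ccc(-c2cs/c(=N/NC(=O)CSc3nnnn3-c3ccccc3)n2-c2ccccc2)cc1`: 28.5%
Compound 2 `Cc1ccc(-c2cs/c(=N/NC(=O)CSc3nnnn3C)n2-c2ccccc2)cc1`: 39.7%
Compound 3 `O=C(CSc1nnnn1-c1ccccc1)N/N=c1/scc(-c2ccccc2)n1-c1ccccc1`: 35.8%

In a functional assay on C6 cells (Rattus norvegicus) for cytotoxicity, read by MTT assay, with a stated time of 24 h, tested at 100 ug/mL (a higher number here means a weaker effect of the compound at the concentration tested, a lower number a stronger effect), compound 1 gives 28.5%, the lowest of the three numbers. One change, (methyl in place of phenyl on an aromatic nitrogen), produced a number 11.2 percentage points higher from compound 1 to compound 2 (beyond the scatter). Compound 3 differs from compound 1 in its core by hydrogen in place of methyl on an aromatic carbon, and that gave a number 7.3 percentage points higher from compound 1 to compound 3 (within the scatter).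

Compound 4 `Cn1nnnc1SCC(=O)N/N=c1/scc(-c2ccccc2)n1-c1ccccc1` is not yet measured. It differs from compound 3 by methyl in place of phenyl on an aromatic nitrogen, the same change that separates compound 1 from compound 2, at the same place. Because that change gave a number 11.2 percentage points higher from compound 1 to compound 2 (beyond the scatter), a step of similar size is expected here, a number 10.2 percentage points higher from compound 3 to compound 4 (beyond the scatter), though it rests on a single measured pair. Compound 4 is therefore estimated at 46%, with a likely range from 36% to 58%.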

Compound 4, a percentage reported as activity, at one concentration (the size of the read-out at that concentration, not a potency): 38.8%
Beside the measured number, compound 4's estimate is 7.2 percentage points above it, and the stated range covers the measured number.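

In this assay, methyl in place of phenyl on an aromatic nitrogen gave a number 3 percentage points higher from compound 3 to compound 4 (within the scatter), and hydrogen in place of methyl on an aromatic carbon gave a number 0.9 percentage points lower from compound 2 to compound 4 (within the scatter). The two steps for the methyl change do not clearly differ, which fits a change that carries from one core to the other, but one pair on each core cannot show that its size is fixed: the same change on two cores in this assay, a number 11.2 percentage points higher (beyond the scatter) from compound 1 to compound 2 and a number 3 percentage points higher (within the scatter) from compound 3 to compound 4, 8.2 percentage points apart, within the scatter of two such steps. The hydrogen change reads the same way, with the same limit: the same change on two cores in this assay, a number 7.3 percentage points higher (within the scatter) from compound 1 to compound 3 and a number 0.9 percentage points lower (within the scatter) from compound 2 to compound 4, 8.2 percentage points apart, within the scatter of two such steps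

The compounds shown leave open how an ethyl group, a longer chain or an amine would read on that aromatic nitrogen. They also leave open whether either change holds on any other core.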